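The source may hold more compounds than are shown below. What is called first, only, known or untested is meant among the compounds shown, and "the series" means these compounds.

Working notes on the thiazole acetic acid series.

Three compounds have numbers in an in vitro assay on HEK385-7 cells for displacement of a labelled ligand from prostaglandin D2 receptor 2 (Homo sapiens); on this read-out higher numbers stand for weaker inhibition and lower numbers for stronger inhibition. Compound 1, `O=C(O)Cc1sc(COc2ccc(Cl)cc2)nc1-c1ccc(Cl)cc1`, gives 32 nM in this assay. Compound 2, `O=C(O)Cc1sc(C(c2ccccc2)c2ccccc2)nc1-c1ccccc1`, gives 570 nM in this assay. Compound 3, `O=C(O)Cc1sc(C(c2ccc(F)cc2)c2ccc(F)cc2)nc1-c1ccnc(F)c1`, gives 0.48 nM in this assay. Compound 3 stands lowest of the three numbers; its nearest neighbour is compound 1 and its furthest is compound 2, and both gaps lie beyond the usual scatter. Among the compounds with values here, no two measured compounds differ in one place only, so no single step can be read off; compound 2 and compound 3 differ at the aryl group on the core as well as at the two rings on the large group, and compound 1 differs from both at more than one place.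

The next compound, compound 4, is `O=C(O)Cc1sc(C(c2ccc(F)cc2)c2ccc(F)cc2)nc1-c1ccco1`. It differs from compound 3 as follows: furan-2-yl in place of 2-fluoropyridin-4-yl on an aromatic carbon. Within the data shown here, the two rings on the large group are kept, so compound 4 keeps what compound 3 shares with no other measured compound.

Among the measured compounds shown here, with no matched step to lean on, the expectation for the step in this assay is a moderate rise in the number, beyond the scatter, estimated as a 6.3-fold higher number from compound 3 to compound 4 (0.80 log units; beyond the scatter). Compound 4 is therefore estimated at 3 nM in this assay, within a range from 0.8 nM to 15 nM.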

Compound 4, half-maximal inhibitory concentration: 18 nM
Beside the measured number, compound 4's estimate is 6.0-fold (0.78 log units) below it; measured number above the stated range.
By their numbers in this assay, from the lowest: compound 3; then compounds 4 and 1 (each within the scatter of the next); then compound 2.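

In this assay, within the data shown here, the change from 2-fluoropyridin-4-yl to furan-2-yl on the aromatic carbon next to the ring nitrogen gives a 38-fold higher number from compound 3 to compound 4 (1.57 log units; beyond the scatter) and is the first change read at a single place. Among these compounds, with the large group and the carboxymethyl group held constant, this position alone moves the number by a large step, which the earlier compounds, all differing at more than one place, could not show. Nothing measured here accounts for the size of this step.

The compounds shown leave open how much of the step goes with the fluorine and how much with the ring that carries it: pyridin-4-yl without fluorine would address the first part, and thiophen-2-yl in place of furan-2-yl would test the five-membered ring with a different hetero atom. Also open, from the compounds shown here alone, is whether a step of this size at this position recurs when the two fluorinated rings on the large group are replaced, for example by the 4-chlorophenoxymethyl group of compound 1.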